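Replacing 3-chlorophenyl with furan-2-yl on a shared core

The compounds below may be only part of what the source reports. "The series", "measured", "known", "first", "only" and "open" are said of these compounds alone.

In a functional assay on MGC-803 cells (Homo sapiens) for cytotoxicity, read by MTT assay, with a stated time of 72 h (on this read-out higher numbers stand for weaker inhibition and lower numbers for stronger inhibition), compound 1 `O=C1C(=Cc2ccc(F)cc2)C(=O)N(c2ccc(Cl)cc2)N1c1ccc(Cl)cc1` gives 26000 nM, compound 2 `COc1cccc(C=C2C(=O)N(c3ccc(Cl)cc3)N(c3ccc(Cl)cc3)C2=O)c1O` gives 24300 nM and compound 3 `O=C1C(=Cc2cccc(Cl)c2)C(=O)N(c2ccc(Cl)cc2)N1c1ccc(Cl)cc1` gives 14400 nM. Compound 3 thus stands within the scatter of both others, so these three cannot be ranked. Compound 4 `O=C1C(=Cc2ccco2)C(=O)N(c2ccc(Cl)cc2)N1c1ccc(Cl)cc1` has furan-2-yl in place of 3-chlorophenyl on a double-bonded chain carbon bound to a double-bonded ring carbon. Three measured swaps at this place bear on it: a 1.1-fold lower number from compound 1 to compound 2 (0.03 log units; within the scatter), a 1.8-fold lower number from compound 1 to compound 3 (0.26 log units; within the scatter) and a 1.7-fold lower number from compound 2 to compound 3 (0.23 log units; within the scatter). All stay within the scatter, although none of these compounds carries a five-membered aromatic ring there. No step beyond the scatter is therefore expected in this assay. The expected step is a 1.4-fold higher number from compound 3 to compound 4 (0.14 log units; within the scatter). For compound 4 the estimated value is 20000 nM, with an expected range of 9000 nM to 45000 nM.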

Compound 4, half-maximal inhibitory concentration: 12800 nM
For compound 4 the middle estimate is 1.6-fold (0.19 log units) above the measured one, and the stated range covers the measured number.
By their numbers in this assay, from the lowest: compounds 4, 3, 2 and 1 (each within the scatter of the next, the first and the last beyond it).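

In this assay, furan-2-yl shows that a five-membered aromatic ring with 1 hetero atom fits at this place: the swap gives a 1.1-fold lower number from compound 3 to compound 4 (0.05 log units; within the scatter) and a 1.9-fold lower number from compound 2 to compound 4 (0.28 log units; within the scatter), both within the scatter. Against 4-fluorophenyl it gives a 2.0-fold lower number from compound 1 to compound 4 (0.31 log units; beyond the scatter), the only step in this set beyond the scatter, and a modest one. No measurement shown explains that step. From the compounds shown here alone, whether thiophene-2-yl would behave like furan-2-yl remains open. So does whether an amine or a carboxylic acid at this place would shift the number further.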